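Cyclohexylmethoxy in place of benzyloxy: cytotoxicity outlook

A few compounds are considered here, and "the series" means these few. Any claim that something is new, unique, unknown or untested is made for them only; others in the source may bear on it.

Measured so far in an ADME assay on HEL cells (Homo sapiens) for cytotoxicity, with a stated time of 3 days; on this read-out higher numbers stand for lower toxicity in this test and lower numbers for higher toxicity in this test:
compound 1 `CCC1(Cc2ccccc2)OS(=O)(=O)C=C1OCc1ccccc1` gives 200000 nM in this assay;
compound 3 `CCCC1(Cc2ccccc2)OS(=O)(=O)C=C1OCc1ccccc1` gives 200000 nM in this assay;
compound 2 `CCC1(Cc2ccccc2)OS(=O)(=O)C=C1OCC#N` gives > 200000 nM in this assay, which is a limit of the assay and not a number.

Compound 1 stands level with compound 3 at the digits shown, the step of no change at the digits printed from compound 1 to compound 3 (within the scatter) lying within the scatter. As far as these compounds go, the step of a number no lower from compound 1 to compound 2 (the limit leaves the size open) changes the same position as the one now considered, but its size stays open because of the limit of > 200000 nM in this assay, at which 1 of the 3 values shown sits.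

Compound 4 `CCC1(Cc2ccccc2)OS(=O)(=O)C=C1OCC1CCCCC1` differs from compound 1 by cyclohexyl in place of phenyl on a saturated chain carbon bound to an oxygen on an unsaturated carbon. Both known steps give no step beyond the scatter, so none is expected here. Compound 4 is estimated at 200000 nM, between 100000 nM and 400000 nM. The expected step is no change at the digits printed from compound 1 to compound 4 (within the scatter).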

Compound 4, half-maximal cytotoxic concentration: > 200000 nM
Compound 4: only a limit was reported; the forecaster's own chance of this, stated with the estimate: 50%; the middle value lies on the limit itself.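

In this assay, the position on a saturated chain carbon bound to an oxygen on an unsaturated carbon also accepts a non-aromatic ring, with a number no lower from compound 1 to compound 4 (the limit leaves the size open). For compound 4, > 200000 nM is a limit of the assay and not a number. The size of this step and the step between compound 2 and compound 4 cannot be read: the limit of > 200000 nM in this assay, at which 2 of the 4 values shown sit.

As far as these compounds go, whether an amine or a carboxylic acid in place of phenyl at this position would give a lower number in this assay stays open. So does any readable ranking among phenyl, cyclohexyl and cyano here.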